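Adding a methoxycarbonyl group to compound 1

A few compounds are considered here, and "the series" means these few. Any claim that something is new, unique, unknown or untested is made for them only; others in the source may bear on it.

In a functional assay on A-375 cells (Homo sapiens) for antiproliferative activity, read by CCK-8 assay, with a stated time of 72 h (on this read-out higher numbers stand for weaker inhibition and lower numbers for stronger inhibition), compound 1 `Nc1ccccc1NC(=O)c1ccc(CSC(=S)N2CCc3ccccc32)cc1` gives 4050 nM. Compound 2 `CC1CCCCN1C(=S)SCc1ccc(C(=O)Nc2ccccc2N)cc1` gives 2610 nM, and compound 3 `CCN(Cc1ccncc1)C(=S)SCc1ccc(C(=O)Nc2ccccc2N)cc1` gives 1940 nM. Compound 1 stands at the high end of these three numbers, with a 1.6-fold lower number from compound 1 to compound 2 (0.19 log units; within the scatter) and a 2.1-fold lower number from compound 1 to compound 3 (0.32 log units; beyond the scatter). The remaining pair shows a 1.3-fold lower number from compound 2 to compound 3 (0.13 log units; within the scatter).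

Compound 4 `COC(=O)c1ccc2c(c1)CCN2C(=S)SCc1ccc(C(=O)Nc2ccccc2N)cc1` keeps the group that compound 1 carries on its thiocarbonyl carbon and changes it in one place: methoxycarbonyl in place of hydrogen on an aromatic carbon. Each measured step replaces the whole group on the thiocarbonyl carbon, so none of them tests a methoxycarbonyl directly. They offer only a rough guide to size, and the largest is a 2.1-fold lower number from compound 1 to compound 3 (0.32 log units; beyond the scatter), which is a modest step. With no closer comparison available, no step beyond the scatter is expected in this assay, and the data give no firm direction. The estimated step is a 1.1-fold lower number from compound 1 to compound 4 (0.03 log units; within the scatter). Compound 4 is expected at about 3800 nM, with an estimated range from 1500 nM to 9500 nM.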

Compound 4, half-maximal inhibitory concentration: 5880 nM
For compound 4 the middle estimate is 1.5-fold (0.19 log units) below the measured one; low and high end bracket the measured number.
By their numbers in this assay, from the lowest: compounds 3, 2, 1 and 4 (each within the scatter of the next, the first and the last beyond it).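

Methoxycarbonyl in place of hydrogen on an aromatic carbon, meta to a fused ring and para to a fused ring, alters the group on the thiocarbonyl carbon without replacing it whole. In this assay, this change gives a 1.5-fold higher number from compound 1 to compound 4 (0.16 log units; within the scatter). This single comparison therefore shows that methoxycarbonyl at this place does not move the number beyond the usual scatter, and no information on why that is so is available.

With only methoxycarbonyl and hydrogen compared at this place, no trend can be drawn for the position. On these data alone, whether a carboxylic acid, an amine or a longer chain there would give a step beyond the scatter stays open, as does the effect of methoxycarbonyl on another aromatic carbon of the same ring.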